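The compounds below may be only part of what the source reports. "The series", "measured", "known", "first", "only" and "open" are said of these compounds alone.

Compound 1 `Cc1cc(C)nc(Oc2ccc(NC(=O)Nc3ccc(F)cc3)cc2)n1` gives > 50000 nM in a functional assay on MCF7 cells (Homo sapiens) for cytotoxicity, read by MTT assay, with a stated time of 3 days; on this read-out higher numbers stand for weaker inhibition and lower numbers for stronger inhibition.
Compound 2 `Cc1cc(C)nc(Oc2ccc(NC(=O)Nc3ccc(Cl)cc3)cc2)n1` gives > 50000 nM in this assay.
Compound 3 `Cc1cc(C)nc(Oc2ccc(NC(=O)Nc3ccc(Cl)cc3Cl)cc2)n1` gives 47800 nM in this assay.

The value of compound 1 is a limit of the assay, not a number. The value of compound 2 is likewise a limit. Compound 3 is therefore the only one of the three with a measured number, and it sits close to the limit of > 50000 nM in this assay, at which 2 of the 3 values shown sit. The steps among the measured compounds are small or unreadable: a step that the two limits leave unreadable from compound 1 to compound 2, an at least 1.0-fold lower number from compound 1 to compound 3 (0.01 log units; that floor lies within the scatter) and an at least 1.0-fold lower number from compound 2 to compound 3 (0.01 log units; that floor lies within the scatter). All three concern the halogen pattern on the phenyl ring attached to the urea, not the linker between the other phenyl ring and the pyrimidine.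

Compound 4 `Cc1cc(C)nc(Sc2ccc(NC(=O)Nc3ccc(Cl)cc3Cl)cc2)n1` is the next compound, and it differs from compound 3 only in that linker: (4,6-dimethylpyrimidin-2-yl)sulfanyl in place of (4,6-dimethylpyrimidin-2-yl)oxy on an aromatic carbon. Among the measured compounds shown here, none of the measured steps touches this part of the shared core, so no measured step bears on it directly. Everything measured so far is weak or beyond the limit, and nothing shows that swapping the oxygen for sulfur changes that. The expected step in this assay is therefore none beyond the scatter, with the estimated change being a 1.2-fold lower number from compound 3 to compound 4 (0.08 log units; within the scatter). For compound 4 the estimated value in this assay is 40000 nM, within a range from 15000 nM to 100000 nM.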

Compound 4, half-maximal inhibitory concentration: > 50000 nM
Compound 4 gave a limit, no number; the forecaster's own chance of this, stated with the estimate: 45%; middle value at least 1.2-fold (0.09 log units) from the limit.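

Among the compounds shown here, this is the first comparison that touches the linker rather than the halogen pattern: (4,6-dimethylpyrimidin-2-yl)sulfanyl in place of (4,6-dimethylpyrimidin-2-yl)oxy gives an at least 1.0-fold higher number from compound 3 to compound 4 (0.01 log units; that floor lies within the scatter) in this assay. The value of compound 4 is a limit and not a number, so the true size of this step cannot be read, and nothing here shows that sulfur in place of oxygen brings a lower number. Compound 3 is still the only compound with a measured number, and the remaining values all fall at one point: the limit of > 50000 nM in this assay, at which 3 of the 4 values shown sit.

The compounds shown leave open whether any other linker at this position, such as an amine nitrogen or a methylene carbon in place of the oxygen or sulfur, would give a clearly lower number in this assay. Also open, from the compounds shown here alone, is what a methoxy or an amino group would do in place of the methyl groups on the pyrimidine, a part that stays the same in all four compounds.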